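Swapping a hydroxyphenyl for a dichlorophenyl on one core

The source may report more compounds than this note shows. Statements on the series, on what has been measured and on what is new or still open speak of the compounds shown alone.

Three compounds share one core and differ only in the aromatic ring attached to a carbon with a double bond to nitrogen. Compound 1 `COc1ccc(OC)c(/C=N/NC(=O)Nc2ccc(Oc3ccnc(-c4nncn4CCN(C)C)c3)c(F)c2)c1` carries a 2,5-dimethoxyphenyl there, and in a functional assay on MKN-45 cells (Homo sapiens) for cytotoxicity, read by MTT assay, with a stated time of 72 h (a higher number here means a weaker inhibitor, a lower number a stronger inhibitor), compound 1 gives 1510 nM. Compound 2 `CN(C)CCn1cnnc1-c1cc(Oc2ccc(NC(=O)N/N=C/c3cccc(O)c3)cc2F)ccn1` carries a 3-hydroxyphenyl; in this assay compound 2 gives 1370 nM, the second highest of the three numbers. The two sit close: a 1.1-fold lower number from compound 1 to compound 2 (0.04 log units; within the scatter). Compound 3 `CN(C)CCn1cnnc1-c1cc(Oc2ccc(NC(=O)N/N=C/c3ccc(Cl)cc3)cc2F)ccn1` carries a 4-chlorophenyl, and in this assay compound 3 gives 570 nM, so that a 2.6-fold lower number from compound 1 to compound 3 (0.42 log units; beyond the scatter).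

Compound 4 `CN(C)CCn1cnnc1-c1cc(Oc2ccc(NC(=O)N/N=C/c3cccc(Cl)c3Cl)cc2F)ccn1` is not yet measured. It differs from compound 2 in one place: 2,3-dichlorophenyl in place of 3-hydroxyphenyl on a carbon with a double bond to nitrogen. The step that bears most on this is the modest gain seen when a chlorine-bearing phenyl entered, a 2.4-fold lower number from compound 2 to compound 3 (0.38 log units; beyond the scatter), and the step from compound 1 to compound 3 points the same way. A modest lowering of the number is therefore expected, a 2.3-fold lower number from compound 2 to compound 4 (0.36 log units; beyond the scatter). Compound 4 is expected to give about 600 nM in this assay, with a likely range from 250 nM to 1500 nM.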

Compound 4, half-maximal inhibitory concentration: 51 nM
Beside the measured number, compound 4's estimate is 12-fold (1.07 log units) above it, outside the stated range (below it).
By their numbers in this assay, from the lowest: compound 4; then compound 3; then compounds 2 and 1 (each within the scatter of the next).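

The earlier compounds shown here suggested that this position moved the number only modestly, yet the 2,3-dichlorophenyl gives far larger steps: a 27-fold lower number from compound 2 to compound 4 (1.43 log units; beyond the scatter) and a 30-fold lower number from compound 1 to compound 4 (1.47 log units; beyond the scatter). Chlorine on the phenyl ring is also not enough on its own to explain the result, as compound 3 already carries a 4-chlorophenyl and there is still an 11-fold lower number from compound 3 to compound 4 (1.05 log units; beyond the scatter), which makes compound 4 the strongest inhibitor of the four in this assay. No measurement shown here accounts for this large gain.

The 4-chlorophenyl and the 2,3-dichlorophenyl differ in both the number and the placement of their chlorines, so the compounds shown cannot separate these two changes. As far as these compounds go, how a phenyl ring carrying bromine atoms or methyl groups in place of the chlorines would compare also remains open.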